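Removing one fluoro group from compound 2

The source may hold more compounds than are shown below. What is called first, only, known or untested is meant among the compounds shown, and "the series" means these compounds.

Compound 1 `Nc1ccc(-c2nc3ccc(F)cc3s2)cc1I`: < 10 nM
Compound 2 `Cc1cc(-c2nc3cc(F)c(F)cc3s2)ccc1N`: < 10 nM

In a functional assay on IGROV-1 cells (Homo sapiens) for inhibition (on this read-out higher numbers stand for weaker inhibition of growth and lower numbers for stronger inhibition of growth), compound 2 stands at < 10 nM, which is a limit of the assay and not a number. Compound 1 is reported only as a limit too, and the measured picture comes down to the limit of < 10 nM in this assay, at which 2 of the 2 values shown sit. Neither compound can therefore be ranked against the other.

The next compound, compound 3 `Cc1cc(-c2nc3ccc(F)cc3s2)ccc1N`, has hydrogen in place of fluoro on an aromatic carbon of compound 2 (hydrogen in place of fluoro on an aromatic carbon). The change falls on a six-membered aromatic ring of carbon only, part of a fused or bridged system of two rings, ortho to a fluoro group, and that remaining fluoro group stays. Among the measured compounds shown here, no two measured compounds differ in one place, so the data offer no measured size for this change. Compound 3 keeps a single fluoro group on the core, as compound 1 does, and compound 1 sits at the limit < 10 nM. On that basis, the estimated step that the limit leaves unreadable from compound 2 to compound 3 is expected to stay within the scatter, with no clear direction. For compound 3 the expected value is 5 nM, with an estimated range of 1 nM to 30 nM.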

Compound 3, concentration for 50% growth inhibition: 1300 nM
Estimate against measurement, compound 3: 260-fold (2.41 log units) below; the whole stated range lies below it.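

In this assay, the fluoro group on this aromatic carbon, ortho to the fluoro group that stays, proves decisive for compound 2: hydrogen in its place gives an at least 130-fold higher number from compound 2 to compound 3 (2.11 log units; beyond the scatter). The methyl-for-iodo change gives a step of similar reach, an at least 130-fold higher number from compound 1 to compound 3 (2.11 log units; beyond the scatter), so a single fluoro group on the core, shared by compound 1 and compound 3, does not by itself keep a compound at the limit, and the iodo and methyl groups are not interchangeable when that fluoro group is the only one. Both steps are minimum sizes, since each starts from a compound reported only as a limit of the assay: the limit of < 10 nM in this assay, at which 2 of the 3 values shown sit.

The compounds shown leave open how far growth inhibition in compound 1 and compound 2 truly extends, and so how large either step really is. Among the compounds shown here, they also leave open whether a chloro group or a methoxy group on the same aromatic carbon would behave like fluoro or like hydrogen, and whether a bromo group in place of methyl would restore growth inhibition when only one fluoro group remains on the core.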